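Acyl variation on the ester of compound 2

A few compounds are considered here, and "the series" means these few. Any claim that something is new, unique, unknown or untested is made for them only; others in the source may bear on it.

Measured so far in an assay on HeLa cells for inhibition of DNA topoisomerase 1 (Homo sapiens); on this read-out lower numbers stand for stronger inhibition and higher numbers for weaker inhibition:
compound 1 `CC(C)=CC[C@@H](OC(=O)CCl)C1=CC(=O)c2c(O)ccc(O)c2C1=O` gives 137000 nM
compound 2 `C/C=C/C=C/C(=O)O[C@H](CC=C(C)C)C1=CC(=O)c2c(O)ccc(O)c2C1=O` gives 130000 nM

Compound 2 has the lowest of the two numbers; its step to compound 1 lies within the scatter. Compound 3 `CCCCCCC(=O)O[C@H](CC=C(C)C)C1=CC(=O)c2c(O)ccc(O)c2C1=O` differs from compound 2 by hexyl in place of penta-1,3-dien-1-yl on a carbonyl carbon. Going by the values given here, the one step that bears on this, the acyl exchange a 1.1-fold lower number from compound 1 to compound 2 (0.02 log units; within the scatter), was within the scatter, so a further acyl exchange is expected to leave this assay essentially unchanged, no step beyond the scatter in either direction. For compound 3 the estimate is 130000 nM, range 65000 nM to 260000 nM, which means an expected step of no change at the digits printed from compound 2 to compound 3 (within the scatter).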

Compound 3, half-maximal inhibitory concentration: 625000 nM
For compound 3 the middle estimate is 4.8-fold (0.68 log units) below the measured one, and the stated range ends below it.
By their numbers in this assay, from the lowest: compounds 2 and 1 (each within the scatter of the next); then compound 3.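

In this assay, going by these compounds alone, the acyl group of this ester is not a silent position: hexyl in place of penta-1,3-dien-1-yl gives a 4.8-fold higher number from compound 2 to compound 3 (0.68 log units; beyond the scatter), the first step beyond the scatter. Pentyl in place of chloro on the saturated chain carbon bound to a carbonyl carbon gives a 4.6-fold higher number from compound 1 to compound 3 (0.66 log units; beyond the scatter), in the same direction. Nothing available explains this shift.

Hexyl differs from penta-1,3-dien-1-yl in both carbon count and double bonds, and a pentyl group on the carbonyl carbon would separate the two. Also open, as far as these compounds go, is how a longer chain, such as octyl, or an acyl group carrying an amine would read.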